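Indazole for fluoropyridine on the shared core

The compounds below may be only part of what the source reports. "The series", "measured", "known", "first", "only" and "open" are said of these compounds alone.

Compound 3 `Nc1ccc(S(=O)(=O)N2CCN(c3ncc(C(O)(C(F)(F)F)C(F)(F)F)cc3-c3cnccc3F)CC2)cn1` gives 17 mL.min-1.g-1 in an ADME assay (liver) for metabolic stability, with Liver microsome (Homo sapiens) as the target, using microsomes and NADPH, with a stated time of 30 min, tested at 1 uM; a lower number here means slower removal, a higher number faster removal of the compound. Compound 2 `NC(=O)c1cccc(-c2cc(C(O)(C(F)(F)F)C(F)(F)F)cnc2N2CCN(S(=O)(=O)c3ccc(N)nc3)CC2)c1` gives 17 mL.min-1.g-1, and the step of no change at the digits printed from compound 2 to compound 3 (within the scatter) leaves compound 3 level with it at the digits shown. Compound 1 `CC(C)(O)C#Cc1cc(C(O)(C(F)(F)F)C(F)(F)F)cnc1N1CCN(S(=O)(=O)c2ccc(N)nc2)CC1` returns only a limit of the assay, < 14 mL.min-1.g-1; (the limit of < 14 mL.min-1.g-1 in this assay, at which 1 of the 3 values shown sits). From there the steps of an at least 1.2-fold higher number from compound 1 to compound 2 (0.08 log units; that floor lies within the scatter) and an at least 1.2-fold higher number from compound 1 to compound 3 (0.08 log units; that floor lies within the scatter) are floors that sit within the scatter.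

Compound 4 `Nc1ccc(S(=O)(=O)N2CCN(c3ncc(C(O)(C(F)(F)F)C(F)(F)F)cc3-c3cccc4[nH]ncc34)CC2)cn1` is not yet measured. The change is 1H-indazol-4-yl in place of 4-fluoropyridin-3-yl on an aromatic carbon. The step from compound 2 to compound 3 swapped one aryl group for another at the same carbon without change, and the two steps from compound 1 are floors within the scatter; so for compound 4 no step beyond the scatter is expected, a 1.2-fold higher number from compound 3 to compound 4 (0.07 log units; within the scatter). Compound 4 is estimated at 20 mL.min-1.g-1, within 10 mL.min-1.g-1 to 40 mL.min-1.g-1.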

Compound 4, intrinsic clearance in microsomes: 42 mL.min-1.g-1
Estimate against measurement, compound 4: 2.1-fold (0.32 log units) below; the measured number lies above the stated range.
By their numbers in this assay, from the lowest: compounds 2 and 3 (each within the scatter of the next); then compound 4. At a limit, below all of these: compound 1.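

In this assay, 1H-indazol-4-yl is the only aryl group shown at this position that separates from the others, with a 2.5-fold higher number from compound 3 to compound 4 (0.39 log units; beyond the scatter) and a 2.5-fold higher number from compound 2 to compound 4 (0.39 log units; beyond the scatter). The position therefore does not treat all aryl groups alike: 4-fluoropyridin-3-yl and 3-carbamoylphenyl sit level, while 1H-indazol-4-yl gives faster removal. Against 3-hydroxy-3-methylbut-1-yn-1-yl, an at least 3.0-fold higher number from compound 1 to compound 4 (0.47 log units; beyond the scatter) is the only step from compound 1 beyond the scatter, and it is a floor set by a limit: the limit of < 14 mL.min-1.g-1 in this assay, at which 1 of the 4 values shown sits.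

The compounds shown do not separate the added ring from the hydrogen-bond donor of 1H-indazol-4-yl. A plain phenyl or a 1-methyl-1H-indazol-4-yl group at this carbon would address that question.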